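The source may report more compounds than this note shows. Statements on the series, on what has been measured and on what is new or still open speak of the compounds shown alone.

In an ADME assay on Vero cells (Chlorocebus sabaeus) for cytotoxicity, read by MTT assay (on this read-out higher numbers stand for lower toxicity in this test and lower numbers for higher toxicity in this test), compound 3 (`Cn1nc(C(F)(F)F)cc1C(=O)Nc1ccc(S(=O)(=O)N2CCC[C@H]2C(=O)O)cc1`) gives > 300000 nM, which is a limit and not a number. It thus stands at the limit of > 300000 nM in this assay, at which 2 of the 3 values shown sit. Compound 4 (`Cn1nc(C(F)(F)F)cc1C(=O)Nc1ccc(S(=O)(=O)NC2CCCCC2)cc1`) has cyclohexylamino in place of 2-carboxypyrrolidin-1-yl on a sulfonyl sulfur. Going by the values given here, two measured steps bear on this. Change at that sulfur gave a step that the two limits leave unreadable from compound 1 to compound 3, and compound 1 (`Cn1nc(C(F)(F)F)cc1C(=O)Nc1ccc(S(=O)(=O)N2CCCCCC2)cc1`), with azepan-1-yl there, gives only a limit, > 300000 nM. Among the compounds with values here, the only step with a readable size, an at least 3.0-fold higher number from compound 2 to compound 3 (0.47 log units; beyond the scatter), removes benzoyl from compound 2 (`Cn1nc(C(F)(F)F)cc1C(=O)Nc1ccc(S(=O)(=O)N2CCC[C@H]2C(=O)OC(=O)c2ccccc2)cc1`), which gives 100000 nM, and it does not touch that sulfur. The expected step, an at least 1.5-fold lower number from compound 3 to compound 4 (0.17 log units; that floor lies within the scatter), is a small fall at most and may not be readable. For compound 4 the estimated value is 200000 nM, with an expected range of 70000 nM to 400000 nM.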

Compound 4, half-maximal cytotoxic concentration: 15000 nM
Compound 4: middle estimate off by 13-fold (1.12 log units), on the high side; measured number below the stated range.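

In this assay, cyclohexylamino on the sulfonyl sulfur gives an at least 20-fold lower number from compound 3 to compound 4 (1.30 log units; beyond the scatter), and also an at least 20-fold lower number from compound 1 to compound 4 (1.30 log units; beyond the scatter). The second step starts from azepan-1-yl, which holds no carboxylic acid, so the fall is not tied to the departure of 2-carboxypyrrolidin-1-yl alone. Both steps are floors and not full sizes, because each starting compound sits at a limit: the limit of > 300000 nM in this assay, at which 2 of the 4 values shown sit.

Whether the fall follows the ring or the hydrogen on the nitrogen stays open, as no compound shown carries piperidin-1-yl or an open-chain hexylamino on that sulfur.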